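The source may hold more compounds than are shown below. What is called first, only, known or untested is meant among the compounds shown, and "the series" means these compounds.

Measured in a functional assay on MCF7 cells (Homo sapiens) for inhibition, read by resazurin assay, with a stated time of 72 h; a higher number here means a weaker inhibitor, a lower number a stronger inhibitor:

compound 1 `CCSc1ccc(C2CC(=O)N2c2cc(OC)c(OC)c(OC)c2)cc1` gives 141 nM
compound 2 `CCOc1ccc(C2CC(=O)N2c2cc(OC)c(OC)c(OC)c2)cc1` gives 64 nM
compound 3 `COc1cc(N2C(=O)CC2c2ccc(SC)cc2)cc(OC)c1OC` gives 67 nM

Compound 1 has the highest number of the three. The steps away from it are modest but beyond the scatter: a 2.2-fold lower number from compound 1 to compound 2 (0.34 log units; beyond the scatter) and a 2.1-fold lower number from compound 1 to compound 3 (0.32 log units; beyond the scatter). Compounds 2 and 3 sit within the scatter of each other, a 1.0-fold higher number from compound 2 to compound 3 (0.02 log units; within the scatter).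

Compound 4 `CCSc1ccc(C2C(C3CC3)C(=O)N2c2cc(OC)c(OC)c(OC)c2)cc1` differs from compound 1 in one place: cyclopropyl in place of hydrogen on a saturated ring carbon. All three measured steps concern the group on the aromatic carbon of the phenyl ring, none touches the four-membered ring of the shared core. Thus no measured step bears on this change, and the direction of any effect is unknown from these data. The working expectation is a step near zero or slightly upward, with wide uncertainty; the estimated step is a 1.4-fold higher number from compound 1 to compound 4 (0.15 log units; within the scatter). Compound 4 is estimated at 200 nM in this assay, with a range of 50 nM to 800 nM.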

Compound 4, half-maximal inhibitory concentration: 606 nM
Estimate against measurement, compound 4: 3.0-fold (0.48 log units) below; measured number inside the range.
By their numbers in this assay, from the lowest: compounds 2 and 3 (each within the scatter of the next); then compound 1; then compound 4.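

In this assay, going by these compounds alone, the first measured change on the four-membered ring of the shared core gives a clear rise in the number (a 4.3-fold higher number from compound 1 to compound 4 (0.63 log units; beyond the scatter)). This saturated ring carbon, next to the ring atom that bears a 4-(ethylsulfanyl)phenyl group, is therefore not indifferent to substitution, and cyclopropyl in place of hydrogen moves the number further than the aromatic change does (a 2.2-fold lower number from compound 1 to compound 2 (0.34 log units; beyond the scatter)). Nothing at hand explains the step.

With cyclopropyl the only group shown on this carbon, it remains open whether the rise is specific to that ring or general to substitution here; a methyl, a hydroxyl or an amine on the same carbon would separate the two. Also open, going by these compounds, is whether the step carries over to the ethoxy and methylsulfanyl analogues, compound 2 and compound 3.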